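Urea ACAT inhibitors: changing the substituent on the pendant aryl

The compounds below may be only part of what the source reports. "The series", "measured", "known", "first", "only" and "open" are said of these compounds alone.

Measured compounds:
compound 1 `CC(C)c1cccc(C(C)C)c1NC(=O)NCC1(c2ccc(C(F)(F)F)cc2)CCCC1` gives 66 nM
compound 2 `CC(C)c1cccc(C(C)C)c1NC(=O)NCC1(c2cccc([N+](=O)[O-])c2)CCCC1` gives 51 nM

In an assay on microsomes for inhibition of acyl-CoA:cholesterol acyltransferase (Oryctolagus cuniculus) (on this read-out lower numbers stand for stronger inhibition and higher numbers for weaker inhibition), compound 2 gives 51 nM, and compound 1 gives 66 nM; the two numbers lie within the usual scatter of each other, so neither stands apart. Among the compounds with values here, the one step of a 1.3-fold lower number from compound 1 to compound 2 (0.11 log units; within the scatter) shows that exchanging the substituent on the pendant aryl ring left the number essentially unchanged. Compound 3 `CC(C)c1cccc(C(C)C)c1NC(=O)NCC1(c2cccc(N(C)C)c2)CCCC1` carries dimethylamino in place of nitro on an aromatic carbon. Within the data shown here, only that single step bears on this change, and it was within the scatter, so a step of a 1.4-fold higher number from compound 2 to compound 3 (0.14 log units; within the scatter) is expected, with no shift beyond the scatter. Compound 3 is therefore estimated at 70 nM, in a range from 20 nM to 250 nM.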

Compound 3, half-maximal inhibitory concentration: 33 nM
Compound 3: middle estimate off by 2.1-fold (0.33 log units), on the high side, within the range that was stated.
By their numbers in this assay, from the lowest: compounds 3, 2 and 1 (each within the scatter of the next).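

In this assay, the step of a 1.5-fold lower number from compound 2 to compound 3 (0.19 log units; within the scatter) shows that dimethylamino can take the place of nitro on this aromatic carbon with no shift beyond the scatter, although the two groups have only their nitrogen in common. The wider exchange of 4-(trifluoromethyl)phenyl for 3-(dimethylamino)phenyl, a 2.0-fold lower number from compound 1 to compound 3 (0.30 log units; within the scatter), also stays within the scatter. No measured evidence accounts for this result. As far as these compounds go, whether a carboxylic acid, a primary amine or a longer alkyl chain on this aromatic carbon would move the number beyond the scatter remains open, as does the effect of an unsubstituted phenyl ring.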